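This account rests on a few compounds, and the source may have more. Where it says the series, first, only, none or still open, it means among the compounds named here.

Measured so far in an ADME assay on BCBL1 cells (Homo sapiens) for cytotoxicity, with a stated time of 7 days (a lower number here means that less compound is tolerated, a higher number that more compound is tolerated), all entries being limits of the assay:
Compound 1 `Nc1nc(OCc2ccccc2)c2ncn(/C=C3/CC3(CO)CO)c2n1`: > 20000 nM
Compound 2 `Nc1nc(NC2CCCCC2)c2ncn(/C=C3/CC3(CO)CO)c2n1`: > 20000 nM
Compound 3 `CSc1nc(N)nc2c1ncn2/C=C1/CC1(CO)CO`: > 20000 nM

Compound 3 stands at > 20000 nM, which is a limit and not a number. For the measured compounds named here, the whole series so far rests on (the limit of > 20000 nM in this assay, at which 3 of the 3 values shown sit).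

The next member, compound 4 `Nc1nc(SC2CCCC2)c2ncn(/C=C3/CC3(CO)CO)c2n1`, differs from compound 3 by cyclopentyl in place of methyl on a sulfur. The nearest measured comparisons replace the whole group on an aromatic carbon: a step that the two limits leave unreadable from compound 1 to compound 3, a step that the two limits leave unreadable from compound 2 to compound 3 and a step that the two limits leave unreadable from compound 1 to compound 2. None of these has a readable size, so they give no direction. The expectation rests on the ring-bearing groups already tested. Compound 1, with benzyloxy, gives the limit > 20000 nM. Compound 2, with cyclohexylamino, gives the limit > 20000 nM.

No step beyond the scatter is therefore expected in this assay, and the expected step is a number no higher from compound 3 to compound 4 (the limit leaves the size open). The estimate for compound 4 is 20000 nM, with an expected range of 9000 nM to 45000 nM, most likely reported only as a limit.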

Compound 4, half-maximal cytotoxic concentration: > 20000 nM
Compound 4 ended at the assay's limit; the forecaster's own chance of this, stated with the estimate: 80%; the middle value sits exactly at the limit.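

No new step can be read from compound 4 to compound 1, compound 2 or compound 3 in this assay, since every entry is a limit: the limit of > 20000 nM in this assay, at which 4 of the 4 values shown sit.

The compounds shown leave open where each half-maximal cytotoxic concentration actually lies, and whether benzyloxy, cyclohexylamino, methylsulfanyl and cyclopentylsulfanyl differ at all.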